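A few compounds are considered here, and "the series" means these few. Any claim that something is new, unique, unknown or untested is made for them only; others in the source may bear on it.

Among the compounds with values here, compound 2 `COc1cc(/C=C/C(=O)C(=Cc2cn(-c3ccccc3)nc2-c2ccccc2O)C(=O)/C=C/c2ccc(O)c(OC)c2)ccc1O` is one of only two compounds so far measured in a functional assay on MCF7 cells (Homo sapiens) for antiproliferative activity, read by MTT assay, with a stated time of 24 h, tested at 0.01 ug/mL; on this read-out higher numbers stand for a weaker effect at the one concentration tested and lower numbers for a stronger effect. In this assay compound 2 gives 93%, the lower of the two numbers, though only by a gap that lies within the scatter. Its nearest neighbour is compound 1 `COc1cc(/C=C/C(=O)C(=Cc2cn(-c3ccccc3)nc2-c2ccc([N+](=O)[O-])cc2)C(=O)/C=C/c2ccc(O)c(OC)c2)ccc1O`, which in this assay gives 95%. Within the data shown here, the single measured step, a number 2 percentage points lower from compound 1 to compound 2 (within the scatter), thus shows no movement beyond the scatter when a 4-nitrophenyl gives way to a 2-hydroxyphenyl on that aromatic carbon.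

Compound 3 `COc1cc(/C=C/C(=O)C(=Cc2cn(-c3ccccc3)nc2-c2cccc([N+](=O)[O-])c2)C(=O)/C=C/c2ccc(O)c(OC)c2)ccc1O` has not yet been tested. It differs from compound 2 by 3-nitrophenyl in place of 2-hydroxyphenyl on an aromatic carbon. Among the measured compounds shown here, the only step that bears on this change is the one just described, in which a nitrophenyl left and a hydroxyphenyl entered at the same aromatic carbon; compound 3 brings a nitrophenyl back at that carbon. Because a number 2 percentage points lower from compound 1 to compound 2 (within the scatter) stayed within the scatter, the step of a number 1 percentage points higher from compound 2 to compound 3 (within the scatter) is expected to show no movement beyond the scatter in either direction. Compound 3 is accordingly expected to give 94% in this assay, with a range from 85% to 100%.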

Compound 3, a percentage reported as activity, at one concentration (the size of the read-out at that concentration, not a potency): 88%
Estimate against measurement, compound 3: 6 percentage points above; the measured number falls inside the stated range.
By their numbers in this assay, from the lowest: compounds 3, 2 and 1 (each within the scatter of the next).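

Within the data shown here, the change at this aromatic carbon of the five-membered aromatic ring again moves nothing beyond the scatter in this assay: 3-nitrophenyl in place of 2-hydroxyphenyl gives a number 5 percentage points lower from compound 2 to compound 3 (within the scatter) and is the first step here to bring a nitrophenyl back at that carbon. Among these compounds, the new compound also allows the first comparison of two nitrophenyl groups, and 3-nitrophenyl in place of 4-nitrophenyl gives a number 7 percentage points lower from compound 1 to compound 3 (within the scatter), so even the largest step among the three compounds does not separate them. Nothing shown here offers an explanation for these numbers.

Going by these compounds, the three compounds all carry a substituted phenyl at this carbon, so it remains open whether an aminophenyl, a carboxyphenyl or a longer alkyl chain there would give a step beyond the scatter in this assay on the same shared core. The read-out also comes from one concentration, so these compounds may or may not differ at other concentrations, and a step seen at this one would say nothing about potency.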